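The compounds below may be only part of what the source reports. "The series", "measured", "known", "first", "only" and "open" are said of these compounds alone.

compound 1 `CCc1nn2c(-c3ccc(OC)cc3Cl)cccc2c1N(CC1CC1)CC1CC1`: 10 nM
compound 2 `CCc1nn2c(-c3c(COC)cc(OC)cc3OC)cccc2c1N(CC1CCOCC1)CC1CC1`: 120 nM
compound 3 `CCc1nn2c(-c3c(C)cc(C)cc3OC)cccc2c1N(CCCF)CC1CC1`: 20 nM

These three compounds were tested in an assay on HEK293 cells for displacement of a labelled ligand from corticotropin-releasing factor receptor 1 (Homo sapiens), read by scintillation counting, with a stated time of 2 h; on this read-out lower numbers stand for stronger inhibition and higher numbers for weaker inhibition. Compound 1 gives the lowest of the three numbers; compound 3 lies within the usual scatter of it, while compound 2 sits well beyond it. Compound 4 `CCc1nn2c(-c3c(C)cc(OC)cc3C)cccc2c1N(CC1CC1)CC1CC1` has not yet been measured. It differs from compound 1 in one place: 4-methoxy-2,6-dimethylphenyl in place of 2-chloro-4-methoxyphenyl on an aromatic carbon. Among the measured compounds shown here, no pair of measured compounds differing only in this way is available, so the effect of the change is not known from the data. Compound 3, with a different ring in this place, gives 20 nM, and the change is therefore expected to be small, in either direction or none beyond the scatter. Compound 4 is estimated at 8 nM, between 3 nM and 25 nM. The expected step of a 1.3-fold lower number from compound 1 to compound 4 (0.10 log units; within the scatter) is small.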

Compound 4, half-maximal inhibitory concentration: 13 nM
Compound 4: the middle estimate sits 1.6-fold (0.21 log units) below what was measured; low and high end bracket the measured number.
By their numbers in this assay, from the lowest: compounds 1, 4 and 3 (each within the scatter of the next); then compound 2.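

Among the compounds shown here, replacing 2-chloro-4-methoxyphenyl with 4-methoxy-2,6-dimethylphenyl in this assay gives a 1.3-fold higher number from compound 1 to compound 4 (0.11 log units; within the scatter) and this is the only direct comparison at this position. It shows that this aromatic carbon accepts both groups, one with chlorine and the other with two methyl groups, with no change beyond the scatter while the rest of compound 1 stays the same. No measurement shown here explains why the two groups read alike.

Going by these compounds, whether a nitrile or trifluoromethyl on the phenyl ring would fit equally well remains open. So does whether this swap would read the same with a different group on the amine nitrogen.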